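The source may hold more compounds than are shown below. What is called first, only, known or untested is meant among the compounds shown, and "the series" means these compounds.

Compound 1 `COc1ccc(NC(=O)Nc2cc(C)nc3ccccc23)cc1`, compound 2 `Cc1cc(NC(=O)Nc2ccc(N)cc2)c2ccccc2n1` and compound 3 `Cc1cc(NC(=O)Nc2ccc(N(C)C)cc2)c2ccccc2n1` share one core and differ only in the group carried on the outer aromatic ring. In an ADME assay on BJ cells (Homo sapiens) for cytotoxicity, with a stated time of 72 h (a higher number here means that more compound is needed for the effect, a lower number that less compound is needed), compound 1 reaches only the limit of the assay, > 25000 nM. Compound 2 likewise gives a limit in this assay, > 25000 nM. Compound 3 gives a limit too, > 25000 nM. Compound 2 thus stands at the limit of > 25000 nM in this assay, at which 3 of the 3 values shown sit, and the steps a step that the two limits leave unreadable from compound 1 to compound 2, a step that the two limits leave unreadable from compound 1 to compound 3 and a step that the two limits leave unreadable from compound 2 to compound 3 cannot be read. Compound 4 `Cc1cc(NC(=O)Nc2cccnc2)c2ccccc2n1` arises from compound 2 through (pyridin-3-yl in place of 4-aminophenyl on an amide-type nitrogen). The measured steps give no size, so the expected step that the limit leaves unreadable from compound 2 to compound 4 is none beyond the scatter. Compound 4 is therefore expected to give 30000 nM in this assay, within 12000 nM to 80000 nM, most likely again only as a limit.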

Compound 4, half-maximal effective concentration: > 25000 nM
Compound 4: a limit, no number; the forecaster's own chance of this, stated with the estimate: 80%; the middle value does not contradict the limit.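

Among the compounds shown here, compound 2 and compound 4 both give only a limit, so no step between them can be read: the limit of > 25000 nM in this assay, at which 4 of the 4 values shown sit. The compounds shown leave open whether any group on the shared core changes the result in this assay, as none of them has a number.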